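A few compounds are considered here, and "the series" means these few. Any claim that something is new, unique, unknown or untested is made for them only; others in the source may bear on it.

Measured in a functional assay on MCF7 cells (Homo sapiens) for inhibition, read by sulforhodamine B assay; on this read-out lower numbers stand for stronger inhibition and higher numbers for weaker inhibition:
- Compound 1 `CCCc1ccc(NC2=CC(=O)c3nc4n(c3C2=O)[C@H]2OC[C@@H](O)[C@H]2OC4)cc1`: 4660 nM
- Compound 2 `CCc1ccc(NC2=CC(=O)c3nc4n(c3C2=O)[C@H]2OC[C@@H](O)[C@H]2OC4)cc1`: 960 nM

Of these two compounds, compound 2 has the lower number, at 960 nM, so it is the stronger inhibitor in this assay. Compound 3 `O=C1C=C(Nc2cccc(F)c2)C(=O)c2c1nc1n2[C@H]2OC[C@@H](O)[C@H]2OC1` has not yet been measured. It differs from compound 2 as follows: 3-fluorophenyl in place of 4-ethylphenyl on an amine nitrogen. In words, it has 3-fluorophenyl in place of 4-ethylphenyl on an amine nitrogen.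

Among the compounds with values here, only one measured step bears on this change: a 4.9-fold lower number from compound 1 to compound 2 (0.69 log units; beyond the scatter). Within the data shown here, that modest step also alters the aromatic group on this nitrogen, but no measured compound carries 3-fluorophenyl, so it gives only a rough idea of size and no firm direction. Among the measured compounds shown here, a small rise, no larger than that step, seems the best guess. The expected change is a 1.4-fold higher number from compound 2 to compound 3 (0.13 log units; within the scatter). For compound 3 the estimated value is 1300 nM, with an expected range of 350 nM to 5000 nM.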

Compound 3, half-maximal inhibitory concentration: 5500 nM
Compound 3: the middle estimate sits 4.2-fold (0.63 log units) below what was measured; measured number outside the range, above it.
By their numbers in this assay, from the lowest: compound 2; then compounds 1 and 3 (each within the scatter of the next).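

In this assay, swapping 4-ethylphenyl for 3-fluorophenyl on the amine nitrogen gives a 5.7-fold higher number from compound 2 to compound 3 (0.76 log units; beyond the scatter) and so costs clear inhibition, which shows that this position does not accept just any substituted phenyl group. Replacing 4-propylphenyl with the same 3-fluorophenyl gives a 1.2-fold higher number from compound 1 to compound 3 (0.07 log units; within the scatter), so compound 2, with its 4-ethylphenyl group, stands alone as the stronger inhibitor of the three. Nothing available explains these differences.

The compounds shown leave open whether the loss comes from removing the ethyl chain, from adding the fluorine, or from moving the substituent around the ring, as all of these change together in compound 3. A plain phenyl, a 4-methylphenyl or a 4-fluorophenyl group would help separate these effects.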